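Shortening the ether chain of compound 1

This account rests on a few compounds, and the source may have more. Where it says the series, first, only, none or still open, it means among the compounds named here.

Compound 1 `CC(C)c1ccc(COc2ccccc2C2CC(=O)c3ccccc3O2)cc1`: 27100 nM
Compound 2 `CCCCOc1ccccc1C1CC(=O)c2ccccc2O1`: 48700 nM

In a functional assay on RAW264.7 cells (Mus musculus) for inhibition, read by Griess assay, with stated times of 1 h and 24 h (a lower number here means a stronger inhibitor, a higher number a weaker inhibitor), compound 1 holds the lower of the two numbers, with compound 2 nearest and within the scatter. Compound 3 `CCOc1ccccc1C1CC(=O)c2ccccc2O1` is not yet measured; it differs from compound 1 by methyl in place of 4-isopropylphenyl on a saturated chain carbon bound to an oxygen on an aromatic ring. Going by the values given here, the one step that bears on this is a 1.8-fold higher number from compound 1 to compound 2 (0.25 log units; within the scatter), which swapped the same group for a propyl chain at the same place. Compound 3 is therefore expected to sit close to compound 1, perhaps a little higher, and its estimated step is a 1.8-fold higher number from compound 1 to compound 3 (0.27 log units; within the scatter). For compound 3 the expected value is 50000 nM, within 20000 nM to 120000 nM.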

Compound 3, half-maximal inhibitory concentration: 38500 nM
Compound 3: middle estimate off by 1.3-fold (0.11 log units), on the high side, and the stated range covers the measured number.
By their numbers in this assay, from the lowest: compounds 1, 3 and 2 (each within the scatter of the next).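

Going from 4-isopropylphenyl to methyl at this place gives a 1.4-fold higher number from compound 1 to compound 3 (0.15 log units; within the scatter) in this assay, so even losing the whole aromatic ring leaves the number within the scatter. The step of a 1.3-fold lower number from compound 2 to compound 3 (0.10 log units; within the scatter) is also within the scatter, so the three ether groups shown cannot be told apart in this assay. Nothing available accounts for this flat result.

On these data alone, it remains open whether an amine or a carboxylic acid on this chain would move the number beyond the scatter. Going by these compounds alone, the same holds for a chain longer than the one in compound 2.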